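Aryl ring swap on the imidazoline series, maximal response

A few compounds are considered here, and "the series" means these few. Any claim that something is new, unique, unknown or untested is made for them only; others in the source may bear on it.

Compound 2 `Cn1cccc1-c1ccccc1NCC1=NCCN1` gives 0% in a functional assay with Alpha-1B adrenergic receptor (Homo sapiens) as the target, read by calcium flux; a lower number here means a smaller maximal response, a higher number a larger maximal response. Compound 1 `Cc1ccc(-c2ccccc2NCC2=NCCN2)n1C` gives 0% in this assay, and compound 3 `CCn1nccc1-c1ccccc1NCC1=NCCN1` gives 0% in this assay, so compound 2 stands level with both at the digits shown, with no change within the scatter to either. For the measured compounds named here, the one measured step, no change at the digits printed from compound 1 to compound 2 (within the scatter), concerns hydrogen in place of methyl on an aromatic carbon and lies within the scatter. Going by the values given here, compound 4 `c1ccc(-c2nc[nH]n2)c(NCC2=NCCN2)c1` is not yet measured in this assay; it differs from compound 2 as follows. 1H-1,2,4-triazol-3-yl in place of 1-methyl-1H-pyrrol-2-yl on an aromatic carbon No measured step addresses a ring swap of this kind, so the step from compound 1 to compound 2 bears only loosely, and compound 3, which carries a different five-membered ring, also sits at the same level as compound 2 and compound 1. On that basis the step from compound 2 to compound 4 is expected to be no change at the digits printed from compound 2 to compound 4 (within the scatter), none beyond the scatter. Compound 4 is accordingly estimated at 0% in this assay, with a range from 0% to 12%.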

Compound 4, largest response reached (reported as maximal response), in percent of the reference or control that the assay uses: 100%
For compound 4 the middle estimate is 100 percentage points below the measured one, outside the stated range (above it).
By their numbers in this assay, from the lowest: compounds 1, 2 and 3 (each within the scatter of the next); then compound 4.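

Placing 1H-1,2,4-triazol-3-yl in place of 1-methyl-1H-pyrrol-2-yl on this aromatic carbon gives a number 100 percentage points higher from compound 2 to compound 4 (beyond the scatter) in this assay. The level readings of compounds 1, 2 and 3, including the methyl-to-hydrogen step on the pyrrole ring, had not shown that this position can carry a group with a full response; the identity of the five-membered ring here can decide between no response and a large one. No measurement on hand accounts for this step, so no feature of the swap can be singled out.

The compounds shown leave open whether 1-methyl-1H-1,2,4-triazol-3-yl, with a methyl on ring nitrogen, or a tetrazol-5-yl ring at this carbon keeps the response of compound 4. Also open, going by these compounds, is whether a group without a ring, such as a carboxylic acid or a primary amide, gives any response at the same carbon.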